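This account rests on a few compounds, and the source may have more. Where it says the series, first, only, none or still open, it means among the compounds named here.

In a functional assay on MCF7 cells (Homo sapiens) (a higher number here means a weaker inhibitor of growth, a lower number a stronger inhibitor of growth), compound 1 (`O=S(=O)(/C=C/c1ccc(O)cc1)Cc1ccc(Nc2ncnc3ccccc23)cc1`) gives 100000 nM and compound 2 (`O=S(=O)(/C=C/c1ccc(Br)cc1)Cc1ccc(Nc2ncnc3ccc(Br)cc23)cc1`) gives 5000 nM as the lower of the two numbers. That gap lies beyond the usual scatter of repeated measurements, so compound 2 is the stronger inhibitor of growth of this pair. The two compounds differ in more than one place, so the gap cannot be pinned on any single group.

Compound 3 (`O=S(=O)(/C=C/c1ccc(O)cc1)Cc1ccc(Nc2ncnc3ccc(Br)cc23)cc1`) has not yet been measured. It departs from compound 2 in one place, on an aromatic carbon of a six-membered aromatic ring of carbon only, para to a large group. There, hydroxy stands in place of bromo (hydroxy in place of bromo on an aromatic carbon), which turns 4-bromophenyl into 4-hydroxyphenyl.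

Going by the values given here, no measured pair shows this change alone, so any expectation is indirect. Compound 1 also carries 4-hydroxyphenyl and gives 100000 nM and this hints at a weaker compound. The expected step is a moderate rise beyond the scatter (a 4.0-fold higher number from compound 2 to compound 3 (0.60 log units; beyond the scatter)). Compound 3 is estimated at 20000 nM (expected range 6000 nM to 70000 nM).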

Compound 3, concentration for 50% growth inhibition: 32000 nM
Compound 3: middle estimate off by 1.6-fold (0.20 log units), on the low side, within the range that was stated.
By their numbers in this assay, from the lowest: compound 2; then compound 3; then compound 1.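

In this assay the exchange of bromo for hydroxy on an aromatic carbon, para to a large group, can now be read alone: it gives a 6.4-fold higher number from compound 2 to compound 3 (0.81 log units; beyond the scatter) and shows that turning 4-bromophenyl into 4-hydroxyphenyl, with the rest of the molecule unchanged, weakens growth inhibition. Compound 3 also isolates a second change, bromo in place of hydrogen on an aromatic carbon of the core, which gives a 3.1-fold lower number from compound 1 to compound 3 (0.49 log units; beyond the scatter) and shows that this second place matters too, since the step with 4-hydroxyphenyl present lies beyond the scatter. No measurement here explains why either change shifts the number.

Going by these compounds, only bromo and hydroxy have been compared at the para position, so it remains open where a group such as methoxy, an amine or a carboxylic acid would fall relative to compound 2 and compound 3. On these data alone, each step has also been read in only one setting, so the effect of the exchange on the phenyl ring with hydrogen on the core, and the effect of bromo on the core with 4-bromophenyl present, remain unknown.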